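The compounds below may be only part of what the source reports. "The series", "measured", "known", "first", "only" and "open" are said of these compounds alone.

Measured in a functional assay on BT-549 cells (Homo sapiens) for inhibition, read by sulforhodamine B assay, with a stated time of 6 days; on this read-out higher numbers stand for weaker inhibition and lower numbers for stronger inhibition:
- compound 1 `CNCCNCc1cccc(-c2nc(NC3CCOCC3)c(C)c(-c3cn(C)nc3C)n2)c1`: > 50000 nM
- compound 2 `CNCCNCc1cccc(-c2nc(Nc3ccccc3)c(C)c(-c3cccnc3)n2)c1`: 14100 nM

Compound 1 gives > 50000 nM, which is a limit of the assay and not a number. Its position is therefore known only as a limit, as the limit of > 50000 nM in this assay, at which 1 of the 2 values shown sits, records. Among the compounds with values here, compound 2 is the only compound so far with a true number, at 14100 nM.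

Next in the series is compound 3 `CNCCNCc1cccc(-c2nc(NC3CCOCC3)c(C)c(-c3cccc4cnccc34)n2)c1`, which keeps the core of compound 1 and its (oxan-4-yl)amino group. The change is isoquinolin-5-yl in place of 1,3-dimethyl-1H-pyrazol-4-yl, on the aromatic carbon ortho to the methyl group: isoquinolin-5-yl in place of 1,3-dimethyl-1H-pyrazol-4-yl on an aromatic carbon.

Within the data shown here, no measured pair isolates this change, so its size in this assay is poorly defined. The expectation leans on compound 2, whose 14100 nM shows that a number can be reached within the series. A modest shift toward stronger inhibition is expected, and a second limit reading remains possible. The expected step is an at least 3.5-fold lower number from compound 1 to compound 3 (0.55 log units; beyond the scatter). For compound 3 the estimated value is 14000 nM, with an expected range of 3000 nM to 50000 nM.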

Compound 3, half-maximal inhibitory concentration: 32000 nM
Estimate against measurement, compound 3: 2.3-fold (0.36 log units) below; measured number inside the range.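

Working notes on the position ortho to the methyl group, with the (oxan-4-yl)amino group held constant. In this assay, isoquinolin-5-yl in place of 1,3-dimethyl-1H-pyrazol-4-yl gives an at least 1.5-fold lower number from compound 1 to compound 3 (0.19 log units; that floor lies within the scatter). This position can therefore carry the larger, two-ring group and still give a true number in this series, with compound 3 at 32000 nM. The step can be read only as a floor, and its true size stays unknown, because compound 1 records a limit of the assay and not a number: the limit of > 50000 nM in this assay, at which 1 of the 3 values shown sits.

Compound 2 differs from compound 3 in more than one place, so it does not separate the contribution of pyridin-3-yl at this position from that of the phenylamino group in place of the (oxan-4-yl)amino group. With only these two groups and the 1,3-dimethyl-1H-pyrazol-4-yl group shown at this position, it remains open whether a plain phenyl or a naphthalen-1-yl group there, which would test the need for the second ring and for the ring nitrogen of isoquinolin-5-yl, would move the number in this assay.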